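Trading Fluoro for Methyl: What Inhibition Might Follow

The source may hold more compounds than are shown below. What is called first, only, known or untested is meant among the compounds shown, and "the series" means these compounds.

Within the data shown here, of the two numbers so far in a functional assay, read by spectrophotometry, with a stated time of 15 min, tested at 60 ug/mL (on this read-out lower numbers stand for a weaker effect and higher numbers for a stronger effect at the one concentration tested), compound 2 `Fc1ccc(-c2csc(N/N=C/c3cccs3)n2)cc1` gives the higher one, 90.3%, though the gap to compound 1 is within the scatter. Among the measured compounds shown here, compound 1 `Clc1ccc(-c2csc(N/N=C/c3cccs3)n2)cc1` in this assay gives 85.2%, and the single measured step, a number 5.1 percentage points higher from compound 1 to compound 2 (within the scatter), shows no movement beyond that scatter. Compound 3 `Cc1ccc(-c2csc(N/N=C/c3cccs3)n2)cc1` differs from compound 2 by methyl in place of fluoro on an aromatic carbon. For the measured compounds named here, no measured step involves a methyl group; the one step available concerns fluoro replacing chloro, a different exchange, so it bears only loosely on this change, and it was flat. The expectation therefore rests on a shared structure with only one small substituent altered. The step expected here, a number 6.3 percentage points lower from compound 2 to compound 3 (within the scatter), is estimated to be small. For compound 3 the estimate in this assay is 84%, expected to fall between 68% and 95%.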

Compound 3, a percentage reported as inhibition, at one concentration (the size of the read-out at that concentration, not a potency): 84.4%
Compound 3: middle estimate off by 0.4 percentage points, on the low side, within the range that was stated.
By their numbers in this assay, from the lowest: compounds 3, 1 and 2 (each within the scatter of the next).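

In this assay at this place, methyl in place of fluoro gives a number 5.9 percentage points lower from compound 2 to compound 3 (within the scatter) and methyl in place of chloro gives a number 0.8 percentage points lower from compound 1 to compound 3 (within the scatter) on the otherwise unchanged core. The earlier pair showed only one halogen exchanged for another, whereas this position on an aromatic carbon, para to a large group, has now also taken a carbon group with no movement beyond the scatter. Nothing available here accounts for this flat result.

The compounds shown leave open whether the same flatness would hold for a different kind of group at this place, such as an amine, a carboxylic acid or a longer chain. Readings at a single concentration also cannot show whether these three compounds would separate in potency.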